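This account rests on a few compounds, and the source may have more. Where it says the series, first, only, none or still open, it means among the compounds named here.

Measured so far in one assay:

compound 1, `CC(C)c1cccc2c(=O)c(-c3nn[nH]n3)c[nH]c12`: 1.25 mg/kg
compound 2, `O=c1c(-c2nn[nH]n2)c[nH]c2c(Cl)ccc(Cl)c12`: > 0.156 mg/kg

Of the compounds shown here, two have been tested in a functional assay on the whole organism (strain Sprague-Dawley) for inhibition, with Rattus norvegicus as the target; on this read-out lower numbers stand for an effect already at smaller amounts and higher numbers for an effect only at larger amounts of compound. Compound 1 gives 1.25 mg/kg. For compound 2 this assay reports only a limit, > 0.156 mg/kg, not a settled number. Where compound 2 stands is therefore known only as one side of a boundary, which is the limit of > 0.156 mg/kg in this assay, at which 1 of the 2 values shown sits. Compound 3, `O=c1c(-c2nn[nH]n2)c[nH]c2c(Cl)cccc12`, has not yet been measured. It differs from compound 2 in a single place: hydrogen in place of chloro on an aromatic carbon. Within the data shown here, no step between two measured compounds is available here, so the effect of this change cannot be read off from a neighbouring pair; it can only be expected. Given that compound 2 sits at a limit and compound 1 at a single number, the step from compound 2 to compound 3 is expected to be a step that the limit leaves unreadable from compound 2 to compound 3, a move toward larger doses that may still fall within the usual scatter. Compound 3 is estimated at 0.6 mg/kg, with a likely range from 0.2 mg/kg to 2 mg/kg, in this assay.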

Compound 3, minimum effective dose: 0.078 mg/kg
For compound 3 the middle estimate is 7.7-fold (0.89 log units) above the measured one, outside the stated range (below it).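

In this assay, hydrogen in place of chloro on this aromatic carbon, para to a chloro group, gives an at least 2.0-fold lower number from compound 2 to compound 3 (0.30 log units; that floor lies within the scatter), so the shared core keeps its effect at small doses without a chloro group at this place. Compound 2 is known only by a limit, so this step gives a floor and not a size: the limit of > 0.156 mg/kg in this assay, at which 1 of the 3 values shown sits. The clearer result concerns the other substituted carbon, where chloro in place of isopropyl gives a 16-fold lower number from compound 1 to compound 3 (1.20 log units; beyond the scatter), a large change that shows the group at that place matters more clearly than anything compound 2 can yet show.

Going by these compounds, the true distance between the two chloro-bearing compounds remains open, and so does whether the gain from hydrogen at this carbon would also appear with isopropyl kept on the other carbon. The compounds shown also leave open what a fluoro, a methoxy or an amine at this carbon would do, and whether a smaller group such as methyl in place of the remaining chloro would hold the effect at small doses.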